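The compounds below may be only part of what the source reports. "The series", "measured", "known", "first", "only" and "open" are said of these compounds alone.

Measured in a functional assay on A549 cells (Homo sapiens) for inhibition, read by MTT assay, with a stated time of 72 h; a higher number here means a weaker inhibitor, a lower number a stronger inhibitor:
compound 1 `O=C(Nc1ccc(Oc2ccnc3[nH]ccc23)cc1)c1cn(-c2ccc(F)cc2)c2ccccc2c1=O` gives 390 nM
compound 2 `Cn1ccc2c(Oc3ccc(NC(=O)c4cn(-c5ccc(F)cc5)c5ccccc5c4=O)cc3F)ccnc21` gives 1460 nM
compound 3 `O=C(Nc1ccc(Oc2ccnc3[nH]ccc23)c(F)c1)c1cn(-c2ccccc2)c2ccccc2c1=O` gives 420 nM

Compound 3 stands second highest of the three numbers. Its nearest neighbour is compound 1, whose number is lower by a margin within the scatter; its furthest is compound 2, whose number is higher by a margin beyond the scatter. No two of the measured compounds differ in only one place, so no single step can be read off from them.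

Compound 4 `O=C(Nc1ccc(Oc2ccnc3[nH]ccc23)c(F)c1)c1cn(-c2ccc(F)cc2)c2ccccc2c1=O` is compound 3 with fluoro in place of hydrogen on an aromatic carbon. Compound 1 already carries a 4-fluorophenyl and gives 390 nM, while compound 3 gives 420 nM, two numbers within the scatter of each other. On that basis the step is expected to be a 1.1-fold lower number from compound 3 to compound 4 (0.02 log units; within the scatter), not beyond the scatter in this assay. Compound 4 is therefore estimated at 400 nM, with a range of 200 nM to 800 nM.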

Compound 4, half-maximal inhibitory concentration: 290 nM
For compound 4 the middle estimate is 1.4-fold (0.14 log units) above the measured one, and the stated range covers the measured number.
By their numbers in this assay, from the lowest: compounds 4, 1 and 3 (each within the scatter of the next); then compound 2.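

In this assay the change from phenyl to 4-fluorophenyl gives a 1.4-fold lower number from compound 3 to compound 4 (0.16 log units; within the scatter) and the other fluoro, on the ring of the shared core, gives a 1.3-fold lower number from compound 1 to compound 4 (0.13 log units; within the scatter) so neither fluoro alone moves the number beyond the scatter. Hydrogen in place of methyl on the aromatic nitrogen gives a 5.0-fold lower number from compound 2 to compound 4 (0.70 log units; beyond the scatter) and is the only step here beyond the scatter. Nothing available bears on the cause of these steps.

Going by these compounds, whether chloro, methoxy or an amine at the place of the 4-fluoro would give a step beyond the scatter stays open. So does the effect of an ethyl or longer chain on the aromatic nitrogen.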